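From an inactive sulfonamide to its fluorophenyl analogue

The source may hold more compounds than are shown below. What is called first, only, known or untested is meant among the compounds shown, and "the series" means these compounds.

Compound 1, `Cc1ccccc1S(=O)(=O)Nc1ccc2oc(-c3ccccc3)nc2c1`: > 63000 nM
Compound 2, `CCc1ccc(S(=O)(=O)Nc2ccc(-c3nc4ccccc4o3)cc2)cc1`: > 63000 nM

Both compounds were tested in an assay on isolated protein for inhibition of malate dehydrogenase, mitochondrial (Sus scrofa), with stated times of 45 min and 30 min; a higher number here means a weaker inhibitor, a lower number a stronger inhibitor. The value for compound 1, > 63000 nM, is a limit of the assay and not a number. The value for compound 2, > 63000 nM, is likewise a limit. Within the data shown here, compound 1 therefore cannot be placed relative to compound 2 on these numbers; the only evidence is the limit of > 63000 nM in this assay, at which 2 of the 2 values shown sit. No step between measured compounds that differ in one place is shown, so no measured effect of any single change is known.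

Compound 3, `O=S(=O)(Nc1ccc2oc(-c3ccccc3)nc2c1)c1cccc(F)c1`, has not yet been measured. It differs from compound 1 in one place: 3-fluorophenyl in place of 2-methylphenyl on a sulfonyl sulfur. Nothing in the two measured values gives a direction for this change. Compound 3 is expected to remain at the limit because the limit of > 63000 nM in this assay, at which 2 of the 2 values shown sit, is all that the two measured compounds show. The expected step that the limit leaves unreadable from compound 1 to compound 3 is therefore none beyond the scatter. Compound 3 is estimated at 100000 nM, in a range from 30000 nM to 400000 nM.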

Compound 3, half-maximal inhibitory concentration: > 63000 nM
Compound 3 gave a limit, no number; the forecaster's own chance of this, stated with the estimate: 85%; the middle value is on the limit's open side.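

Among these compounds, compound 1 and compound 3 each give only a limit in this assay and not a number, so no step between them can be read. The compounds shown leave open how strongly any of them inhibits the enzyme, and whether 3-fluorophenyl or 2-methylphenyl on the sulfonyl sulfur makes any difference.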